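The compounds below may be only part of what the source reports. "The series", "measured", "known", "first", "only" and "open" are said of these compounds alone.

The series shares the core of compound 1 `O=C(NCCCCc1ccccc1)n1c(=O)oc2ccccc21`, which in an assay on HEK293 cells for inhibition of acid ceramidase (Homo sapiens), with a stated time of 10 min (on this read-out lower numbers stand for stronger inhibition and higher numbers for weaker inhibition), gives 64 nM. Compound 2 `O=C(c1ccccc1)c1ccc2c(c1)oc(=O)n2C(=O)NCCCCc1ccccc1` carries a benzoyl group on an aromatic carbon of that core, and in this assay compound 2 gives 29 nM; the step is a 2.2-fold lower number from compound 1 to compound 2 (0.34 log units; beyond the scatter). Compound 3 `O=C(NCCCCc1ccccc1)n1c(=O)oc2cc(F)ccc21` carries fluoro instead, and in this assay compound 3 gives 31 nM, so that a 2.1-fold lower number from compound 1 to compound 3 (0.31 log units; beyond the scatter). Between the two substituted compounds a 1.1-fold higher number from compound 2 to compound 3 (0.03 log units; within the scatter). Compound 3 thus sits second of the three numbers, clearly apart from compound 1 but not separable from compound 2.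

Compound 4 `O=C(NCCCCc1ccccc1)n1c(=O)oc2cc(-c3ccccc3)ccc21` arises from compound 3 by phenyl in place of fluoro on an aromatic carbon. Within the data shown here, no measured step exchanges fluoro for phenyl directly. Among the measured compounds shown here, the steps that bear on it are a 2.1-fold lower number from compound 1 to compound 3 (0.31 log units; beyond the scatter), the step that introduced fluoro, and a 2.2-fold lower number from compound 1 to compound 2 (0.34 log units; beyond the scatter) together with a 1.1-fold higher number from compound 2 to compound 3 (0.03 log units; within the scatter), which show a larger aromatic substituent on the core giving a number indistinguishable from that of fluoro. On this basis no step beyond the scatter in this assay is expected in either direction. The expected step is a 1.0-fold lower number from compound 3 to compound 4 (0.01 log units; within the scatter). For compound 4 the expected value in this assay is 30 nM, with a range from 12 nM to 80 nM.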

Compound 4, half-maximal inhibitory concentration: 84 nM
Beside the measured number, compound 4's estimate is 2.8-fold (0.45 log units) below it; the whole stated range lies below it.
By their numbers in this assay, from the lowest: compounds 2 and 3 (each within the scatter of the next); then compounds 1 and 4 (each within the scatter of the next).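

At this position on the shared core, a substituent does not by itself give the lower number seen with fluoro and benzoyl: in this assay, phenyl reverses the gain, with a 2.7-fold higher number from compound 3 to compound 4 (0.43 log units; beyond the scatter) and a 2.9-fold higher number from compound 2 to compound 4 (0.46 log units; beyond the scatter), while a 1.3-fold higher number from compound 1 to compound 4 (0.12 log units; within the scatter) leaves compound 4 not separable from the unsubstituted core. Compounds 2 and 4 differ only by the carbonyl that joins the benzene ring to the core, so a directly attached phenyl and a benzoyl are not interchangeable here, and the earlier equivalence of fluoro and benzoyl does not extend to every aromatic or larger group. Nothing available accounts for this split among the substituents.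

Still open, going by these compounds, is whether the carbonyl itself is what separates compound 2 from compound 4, which a benzyl or phenoxy group at the same carbon would test. Also open, on these data alone, are how chloro, methoxy, an amine or a carboxylic acid behave at this position, and whether phenyl gives the same result on the other aromatic carbons of the core.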